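The source may report more compounds than this note shows. Statements on the series, on what has been measured and on what is new or still open speak of the compounds shown alone.

Measured so far in an assay on CHO cells for displacement of a labelled ligand from adenosine receptor A3 (Homo sapiens), read by scintillation counting, with a stated time of 60 min; a lower number here means a stronger inhibitor, a higher number a weaker inhibitor:
compound 1 `CC(=O)Nc1nc(C)nc2cn(-c3ccccc3)nc12` gives 300 nM
compound 2 `Cc1nc(NC(=O)c2ccco2)c2nn(-c3ccccc3)cc2n1` gives 20 nM

Going by the values given here, compound 2 stands at the lowest of the two numbers in this assay; its nearest neighbour is compound 1, and the one step between them, a 15-fold lower number from compound 1 to compound 2 (1.18 log units; beyond the scatter), is the only measured step. That step lies at the carbonyl carbon of the amide, not on the ring that carries the aryl substituent.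

Compound 3 `COc1ccc(-n2cc3nc(C)nc(NC(=O)c4ccco4)c3n2)cc1` differs from compound 2 by methoxy in place of hydrogen on an aromatic carbon, on an aromatic carbon of a six-membered aromatic ring of carbon only. Among the compounds with values here, no measured step touches this ring, so the single step from compound 1 to compound 2 does not bear on the change; it only shows that the amide side of the core moves the number strongly, while nothing is known about the aryl side.

Within the data shown here, with no step informing the change, the expectation for compound 3 is a number close to that of compound 2, with a 1.3-fold lower number from compound 2 to compound 3 (0.12 log units; within the scatter) expected to stay within the scatter. Compound 3 is therefore estimated at 15 nM, with a range from 4 nM to 60 nM.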

Compound 3, inhibition constant: 45 nM
The estimate for compound 3 lay 3.0-fold (0.48 log units) below the measured number; the range from low to high includes it.
By their numbers in this assay, from the lowest: compound 2; then compound 3; then compound 1.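

In this assay the aryl side of the shared core now has its first measured step: going from phenyl to 4-methoxyphenyl, with the furan-2-yl amide held fixed, gives a 2.3-fold higher number from compound 2 to compound 3 (0.35 log units; beyond the scatter) and so shows that this position also moves the number, if only modestly. Methoxy on this aromatic carbon, para to a large group, does not give a lower number here, and compound 3 keeps a value of 45 nM in the double-digit nanomolar range. In size, this step is smaller than the one at the amide carbonyl, a 15-fold lower number from compound 1 to compound 2 (1.18 log units; beyond the scatter), though that comparison rests on one step at each site. Nothing available explains why the number rises with methoxy at this position.

One substituent at one place on the phenyl ring cannot show whether the rise belongs to methoxy itself, and a fluorine, a hydroxyl, an amine or a longer ether such as ethoxy at the same carbon would help to separate these cases. On these data alone, it also remains open whether methoxy at another carbon of that ring gives the same step, and whether the step carries over to the methyl amide of compound 1.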